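From piperidin-1-yl to 4-methylpiperazin-1-yl in compound 3

This account rests on a few compounds, and the source may have more. Where it says the series, first, only, none or still open, it means among the compounds named here.

Going by the values given here, in a functional assay on HepG2 cells (Homo sapiens) for antiproliferative activity, read by MTT assay, with a stated time of 48 h (a higher number here means a weaker inhibitor, a lower number a stronger inhibitor), compound 2 `O=C(CN1CCCCC1)Nc1ccc2ncnc(Nc3ccc(Cl)cc3)c2c1` gives 16000 nM, the only exact number so far. Compound 1 `CN1CCN(CC(=O)Nc2ccc3ncnc(Nc4cccc(Cl)c4)c3c2)CC1` reads > 100000 nM, which is a limit of the assay and not a number.

Compound 3 `CN1CCN(CC(=O)Nc2ccc3ncnc(Nc4ccc(Cl)cc4)c3c2)CC1` has not yet been measured. Its difference from compound 2 is 4-methylpiperazin-1-yl in place of piperidin-1-yl on a saturated chain carbon bound to a carbonyl carbon. Among the compounds with values here, no measured step isolates this change, so there is no direct precedent in this assay. A modest step toward weaker inhibition, somewhat beyond the scatter, is expected. That expectation leans on compound 1, whose > 100000 nM is a limit. The estimated step is a 2.5-fold higher number from compound 2 to compound 3 (0.40 log units; beyond the scatter). For compound 3, the expected value is 40000 nM, with an estimated range of 12000 nM to 100000 nM.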

Compound 3, half-maximal inhibitory concentration: > 100000 nM
Compound 3: a limit, no number; the forecaster's own chance of this, stated with the estimate: 30%; at least 2.5-fold (0.39 log units) between middle value and limit.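

Within the 4-chlorophenyl compounds, the change at this position now has a direct reading in this assay: 4-methylpiperazin-1-yl in place of piperidin-1-yl gives an at least 6.2-fold higher number from compound 2 to compound 3 (0.79 log units; beyond the scatter). Compound 3 gives > 100000 nM, which is a limit and not a number, so the step is known only as a minimum size. The step from 3-chlorophenyl to 4-chlorophenyl cannot be read with 4-methylpiperazin-1-yl in place, because both values sit at the same limit: the limit of > 100000 nM in this assay, at which 2 of the 3 values shown sit.

On these data alone, whether the weaker reading follows the added nitrogen or the methyl group stays open; piperazin-1-yl or morpholin-4-yl would separate the two. Also open, as far as these compounds go, is whether a dimethylamino group or a longer chain at this position would give a lower number than compound 2 in this assay.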